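Removing a methyl group and stability in liver microsomes

The source may hold more compounds than are shown below. What is called first, only, known or untested is meant among the compounds shown, and "the series" means these compounds.

Compound 1 `Cc1nc(N)nc2c1c(-c1ccc3oc(N)nc3c1)nn2C(C)C` and compound 2 `CC(C)n1nc(-c2ccc3oc(N)nc3c2)c2cnc(N)nc21` share one core, while compound 3 `Cc1nc2c(c(-c3ccc4oc(N)nc4c3)nn2C(C)C)c(=O)[nH]1` and compound 4 `CC(C)n1nc(-c2ccc3oc(N)nc3c2)c2c(=O)[nH]cnc21` share another; how the two cores differ is not broken down here. Three of the four have been tested in an ADME assay on microsomes from liver (Homo sapiens) for metabolic stability, read by LC-MS, with a stated time of 15 min, tested at 1 uM, in the presence of a further agent that is not named here; on this read-out higher numbers stand for a more stable compound and lower numbers for a less stable compound. In this assay compound 1 reaches a limit of the assay, > 95%. In this assay compound 2 gives 94%. The difference between the two is hydrogen in place of methyl on an aromatic carbon, and the step it made is a number at least 1 percentage points lower from compound 1 to compound 2 (that floor lies within the scatter). In this assay compound 3 also reaches a limit of the assay, > 95%. Worth noting is the limit of > 95% in this assay, at which 2 of the 3 values shown sit.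

Compound 4 has not been measured. From compound 3 it differs by hydrogen in place of methyl on an aromatic carbon. This is the same kind of change as that from compound 1 to compound 2, but its surroundings are not identical: in the measured pair the carbon is next to the ring nitrogen, ortho to a fused ring, meta to an amino group and opposite the ring nitrogen, whereas in compound 4 it lies between two ring nitrogen atoms, meta to a group of 1 heavy atom and para to a fused ring. Resting on the measured step of a number at least 1 percentage points lower from compound 1 to compound 2 (that floor lies within the scatter), compound 4 is expected to show a number at least 3 percentage points lower from compound 3 to compound 4 (that floor lies within the scatter). In this assay compound 4 is estimated at 92%, most likely between 80% and 100%.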

Compound 4, percent of the compound remaining in the Homo sapiens assay: > 95%
Compound 4: only a limit was reported (the forecaster's own chance of this, stated with the estimate: 40%); middle value at least 3 percentage points away from the limit.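

In the Homo sapiens assay compound 3 gives > 95%, which is a limit of the assay and not a number. In the Homo sapiens assay compound 4 gives > 95%, which is also a limit of the assay and not a number. No step can be read from compound 3 to compound 4, as both compounds sit at the same limit of the assay: the limit of > 95% in the Homo sapiens assay, at which 3 of the 4 values shown sit.

In a physicochemical assay for solubility, read by HPLC, in phosphate buffer, measured as kinetic solubility, with a stated time of 24 h, at 20 degrees C, at pH 7.4, tested at 100 uM (on this read-out lower numbers stand for lower solubility and higher numbers for higher solubility), compound 3 gives 3000 nM. In the physicochemical assay compound 4 gives 3000 nM. In the physicochemical assay the values show no change at the digits printed from compound 3 to compound 4 (within the scatter).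

The compounds shown leave open whether hydrogen in place of methyl on an aromatic carbon changes the percent of compound remaining at all.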